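Phenyl on the chain carbon of a thioether pyrimidine

A few compounds are considered here, and "the series" means these few. Any claim that something is new, unique, unknown or untested is made for them only; others in the source may bear on it.

Measured compounds:
Compound 1, `CCOC(=O)C(C)Sc1nc(Cl)cc(Nc2cccc(C)c2C)n1`, reported as "not active" (no number reported), without a number.
Compound 2, `CCOC(=O)CSc1nc(Cl)cc(Nc2ccc3ncccc3c2)n1`, 86.3%.
Compound 3, `CCCCCCC(Sc1nc(Cl)cc(Oc2ccc3ncccc3c2)n1)C(=O)OCC`, 67.4%.

The three measured compounds share a chlorinated pyrimidine core carrying a thioether arm that ends in an ethyl ester. Among the measured compounds shown here, in an assay for inhibition of Polyunsaturated fatty acid 5-lipoxygenase (Homo sapiens), tested at 1 uM (a higher number here means a weaker effect of the compound at the concentration tested, a lower number a stronger effect), compound 2 gives 86.3%, the highest of the two numbers known, that is the weaker effect. The nearest number belongs to compound 3, which in this assay gives 67.4%, a gap that lies beyond the usual scatter. Compound 3 differs from compound 2 in more than one place, so no single step can be read from the pair; the two values only show that the longer-chain ether compound reaches a lower number.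

Compound 4, `CCOC(=O)C(Sc1nc(Cl)cc(Nc2ccc3ncccc3c2)n1)c1ccccc1`, has not been measured. It differs from compound 2 by phenyl in place of hydrogen on a saturated chain carbon bound to a carbonyl carbon and a sulfur. For the measured compounds named here, no step of this kind has been measured, so the direction of the change is open. Compound 4 is expected to move at most modestly, likely toward a somewhat lower number, with a step of a number 8.3 percentage points lower from compound 2 to compound 4 (within the scatter) that may not exceed the scatter. Compound 4 is estimated at 78%, within a range from 55% to 96%.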

Compound 4, a percentage reported as activity, at one concentration (the size of the read-out at that concentration, not a potency): 52.7%
Compound 4: middle estimate off by 25.3 percentage points, on the high side; measured number outside the range, below it.
By their numbers in this assay, from the lowest: compound 4; then compound 3; then compound 2.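

In this assay, the chain carbon bound to a carbonyl carbon and a sulfur turns out to be a sensitive position: phenyl in place of hydrogen there gives a number 33.6 percentage points lower from compound 2 to compound 4 (beyond the scatter), a large step beyond the scatter. The earlier numbers came from compounds that differ in more than one place, whereas this single change ties a clear shift to one position and one group, and it shows that an aromatic ring on this carbon goes with a stronger effect at the concentration tested, not a weaker one. No measurement shown here accounts for the direction or size of this step.

On these data alone, it remains open whether this shift is specific to phenyl or would also appear with a smaller or more flexible group on the same carbon, such as methyl, benzyl or a longer alkyl chain. As far as these compounds go, it is equally open whether the step would carry over to a compound with a carboxylic acid in place of the ethyl ester, or to one with another group in place of the chlorine on the shared core.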